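The compounds below may be only part of what the source reports. "The series", "measured", "known", "first", "only" and "open" are said of these compounds alone.

Compounds measured:
compound 1 `O=C(CCc1cccc2c1B(O)OC2)Nc1ccc2ccccc2c1` – 1400 nM
compound 2 `O=C(CCc1cccc2c1B(O)OC2)Nc1cccc(-c2cccc(F)c2)c1` – 480 nM

In a functional assay on SK-OV-3 cells (Homo sapiens) for antiproliferative activity, read by MTT assay, with a stated time of 72 h (on this read-out higher numbers stand for weaker inhibition and lower numbers for stronger inhibition), compound 2 gives the lowest number of the two, and compound 1 gives a number beyond the scatter above it. Compound 3 `N#Cc1ccc(-c2cccc(NC(=O)CCc3cccc4c3B(O)OC4)c2)cc1` has not been measured. It differs from compound 2 by 4-cyanophenyl in place of 3-fluorophenyl on an aromatic carbon. Among the compounds with values here, no measured pair shows the effect of such a change, so the size of the step is uncertain. An expectation near the value of compound 2, within the scatter in either direction, is stated for a 1.1-fold lower number from compound 2 to compound 3 (0.03 log units; within the scatter). Compound 3 is expected to give 450 nM, with a range from 150 nM to 1400 nM.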

Compound 3, half-maximal inhibitory concentration: 340 nM
The estimate for compound 3 lay 1.3-fold (0.12 log units) above the measured number; the range from low to high includes it.
By their numbers in this assay, from the lowest: compounds 3 and 2 (each within the scatter of the next); then compound 1.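

In this assay, 4-cyanophenyl in place of 3-fluorophenyl gives a 1.4-fold lower number from compound 2 to compound 3 (0.15 log units; within the scatter). Within the data shown here, this is the first measured step at this aromatic carbon, and it shows that the nitrile-bearing ring and the fluorine-bearing ring cannot be told apart here. Nothing available explains this result.

From the compounds shown here alone, because the two names differ in both the group and its number on the ring, 3-cyanophenyl and 4-fluorophenyl remain open. Going by these compounds, how a ring bearing an amine or a carboxylic acid would read at this place is also open.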